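Anilide variation in a porcupine series

A few compounds are considered here, and "the series" means these few. Any claim that something is new, unique, unknown or untested is made for them only; others in the source may bear on it.

Three analogues of one series have been tested in an assay on L cells for inhibition of Protein-serine O-palmitoleoyltransferase porcupine (Mus musculus), read by reporter gene assay, with a stated time of 24 h; a higher number here means that more compound is needed for the effect, a lower number that less compound is needed. Compound 1, `O=C(CNC(=O)c1nn(-c2ccc(F)cc2)c(=O)c2ccccc12)Nc1nc2ccccc2s1`, carries a different core from the others. For compound 1 the assay reports only a limit, > 25000 nM. Compound 2, `O=C(CSc1nc2c(c(=O)n1-c1ccccc1)SCC2)Nc1cccc(-c2ccccc2)c1`, and compound 3, `O=C(CSc1nc2c(c(=O)n1-c1ccccc1)SCC2)Nc1ccc(N2CCCCC2)cc1`, share a core and differ in the anilide part. For compound 2 the result is again a limit, > 5000 nM. Compound 3 is the only one of the three with a number in this assay, where it gives 30 nM. The other two values stand at a limit, as the limit of > 25000 nM in this assay, at which 1 of the 3 values shown sits, and the limit of > 5000 nM in this assay, at which 1 of the 3 values shown sits, show.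

Compound 4, `CCOC(=O)c1ccc(NC(=O)CSc2nc3c(c(=O)n2-c2ccccc2)SCC3)cc1`, keeps the core and the amide of compound 3 and changes one group on the aromatic ring of the anilide: ethoxycarbonyl in place of piperidin-1-yl on an aromatic carbon. Among the measured compounds shown here, no measured step of the same kind is available for this series, so the expectation rests on compound 3 alone and on the fact that compound 2, with another group in that region, gives only a limit. A loss of potency in this assay is expected for compound 4, larger than the usual scatter. Compound 4 is estimated to give 800 nM, with a range from 100 nM to 8000 nM, which means an expected step of a 27-fold higher number from compound 3 to compound 4 (1.43 log units; beyond the scatter).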

Compound 4, half-maximal effective concentration: 300 nM
For compound 4 the middle estimate is 2.7-fold (0.43 log units) above the measured one; measured number inside the range.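

In this assay the position on the aromatic ring of the anilide now has its first measured step: ethoxycarbonyl in place of piperidin-1-yl gives a 10-fold higher number from compound 3 to compound 4 (1.00 log units; beyond the scatter) and the step is beyond the scatter. Piperidin-1-yl is therefore not required for a measured number at this position, since compound 4, whose group has no ring and carries a double bond outside aromatic rings, still gives a value and not a limit, although the number is higher than with piperidin-1-yl. No measurement shown accounts for the size of this step, which rests on a single pair of compounds.

From the compounds shown here alone, it remains open whether the step follows the loss of the ring, the loss of the nitrogen or the entry of the ester, and how a morpholin-4-yl group, a dimethylamino group or a carboxylic acid would read at the same place. Compounds 1 and 2 stand as limits of the assay, and steps to them cannot be read.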